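Adding a Second Methoxy Group to Compound 2

A few compounds are considered here, and "the series" means these few. Any claim that something is new, unique, unknown or untested is made for them only; others in the source may bear on it.

Compound 1 `O=C(N/N=C/c1cccc(F)c1)c1cccnc1Nc1cccc(C(F)(F)F)c1` and compound 2 `COc1ccc(/C=N/NC(=O)c2cccnc2Nc2cccc(C(F)(F)F)c2)cc1` share one core and differ in a single place. In a functional assay on the whole organism (strain Wistar) for inhibition, with Rattus norvegicus as the target, read by paw edema, with a stated time of 2 h, at a dose of 10 mg/kg by the intraperitoneal route (a higher number here means more inhibition at the dose given (going by the name of the read-out), a lower number less inhibition), compound 1 gives 52.8%, while compound 2 gives 42.4%, the lower of the two numbers, the step being a number 10.4 percentage points lower from compound 1 to compound 2 (beyond the scatter). Compound 3 `COc1ccc(/C=N/NC(=O)c2cccnc2Nc2cccc(C(F)(F)F)c2)cc1OC` carries one further change: methoxy in place of hydrogen on an aromatic carbon. Among the measured compounds shown here, no measured step covers an added methoxy; the one step on this ring, a number 10.4 percentage points lower from compound 1 to compound 2 (beyond the scatter), was modest, so compound 3 is expected to shift by a number 2.4 percentage points lower from compound 2 to compound 3 (within the scatter), within the scatter. Compound 3 is thus estimated at 40%, ranging from 28% to 52%.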

Compound 3, a percentage reported as inhibition, in the whole organism at one dose (the size of the read-out at that dose, not a potency): 49%
Beside the measured number, compound 3's estimate is 9 percentage points below it, and the stated range covers the measured number.
By their numbers in this assay, from the lowest: compounds 2, 3 and 1 (each within the scatter of the next, the first and the last beyond it).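

In this assay the methoxy placed ortho to a methoxy group gives a number 6.6 percentage points higher from compound 2 to compound 3 (within the scatter) and so no readable change at this position. The 3,4-dimethoxyphenyl group gives a number 3.8 percentage points lower from compound 1 to compound 3 (within the scatter) while the 4-methoxyphenyl group alone gave a number 10.4 percentage points lower from compound 1 to compound 2 (beyond the scatter) and so only the latter step lies beyond the scatter. No measured evidence accounts for these steps.

As far as these compounds go, whether a hydroxyl group or an amine at this position, or a longer chain such as ethoxy, would read any differently stays open. So does whether a methoxy added to the 3-fluorophenyl group of compound 1 would behave the same way.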